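A few compounds are considered here, and "the series" means these few. Any claim that something is new, unique, unknown or untested is made for them only; others in the source may bear on it.

Measured so far:
- compound 1 `CS/C(=N\C(=O)c1ccno1)NC(=O)c1ccno1`: > 100000 nM
- compound 2 `CS/C(=N\C(=O)c1ccco1)NC(=O)c1ccco1`: > 100000 nM
- compound 3 `O=C(/N=C(/NC(=O)c1ccno1)[Se]Cc1ccccc1)c1ccno1`: 9120 nM

These three compounds were tested in a functional assay on HepG2 cells (Homo sapiens) for cytotoxicity, read by MTT assay, with a stated time of 72 h; on this read-out higher numbers stand for weaker inhibition of growth and lower numbers for stronger inhibition of growth. Compound 1 gives only a limit of the assay, > 100000 nM, not a number. Compound 2 likewise gives only a limit, > 100000 nM. Compound 3 gives a number, 9120 nM.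

Compound 3 is made from compound 1 by one change: a group of 8 heavy atoms (7 carbon, 1 selenium; one six-membered aromatic ring of carbon only) in place of a group of 2 heavy atoms (1 carbon, 1 sulfur; no ring), on a carbon with a double bond to nitrogen. That change produced an at least 10-fold lower number from compound 1 to compound 3 (1.04 log units; beyond the scatter). The starting point of this step is the limit of > 100000 nM in this assay, at which 2 of the 3 values shown sit, so the true size of the step is only known as a lower bound.

Compound 4 `O=C(/N=C(/NC(=O)c1ccco1)[Se]Cc1ccccc1)c1ccco1` has not yet been measured. It is made from compound 2 by the same change, (a group of 8 heavy atoms (7 carbon, 1 selenium; one six-membered aromatic ring of carbon only) in place of a group of 2 heavy atoms (1 carbon, 1 sulfur; no ring), on a carbon with a double bond to nitrogen), at the same place. The difference between the core of compound 1 and the core of compound 2 is not broken down here.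

Because compound 1 went to compound 3 by an at least 10-fold lower number from compound 1 to compound 3 (1.04 log units; beyond the scatter), a similar step is expected here. The step from compound 2 to compound 4 is estimated to be an at least 8.3-fold lower number from compound 2 to compound 4 (0.92 log units; beyond the scatter). Compound 4 is therefore expected to give about 12000 nM in this assay, estimated within a range from 3000 nM to 60000 nM.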

Compound 4, concentration for 50% growth inhibition: 7650 nM
Estimate against measurement, compound 4: 1.6-fold (0.20 log units) above, and the stated range covers the measured number.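

In this assay, the same change, with methylsulfanyl leaving and the selenium group with its six-membered aromatic ring entering, gives an at least 13-fold lower number from compound 2 to compound 4 (1.11 log units; beyond the scatter), so on both cores shown it goes with a large drop in the number. Set side by side, the two steps read as follows: the same change on two cores in this assay, an at least 10-fold lower number (1.04 log units; beyond the scatter) from compound 1 to compound 3 and an at least 13-fold lower number (1.11 log units; beyond the scatter) from compound 2 to compound 4; the limit leaves it open whether they differ. This shows that the change carries over from the core of compound 1 to the core of compound 2 in direction, but it does not show that the step has the same size on both, because each step starts from a limit and not from a number: the limit of > 100000 nM in this assay, at which 2 of the 4 values shown sit.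

The entering group brings selenium and the aromatic ring in a single step, so the compounds shown leave open which of the two goes with the lower numbers. As far as these compounds go, a methylselanyl group or a benzylsulfanyl group on the same carbon would separate the two, and whether the step holds on cores beyond these two also remains open.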